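Dropping the cyanomethylcarbonyl group from compound 2

This account rests on a few compounds, and the source may have more. Where it says the series, first, only, none or still open, it means among the compounds named here.

Values so far in a functional assay on SMMC-7721 cells (Homo sapiens) for inhibition, read by MTT assay; on this read-out higher numbers stand for weaker inhibition and lower numbers for stronger inhibition:
- compound 1 `N#Cc1c(N)sc(C(=O)Nc2ccc(Cl)cc2)c1-c1ccccc1` gives 690 nM
- compound 2 `CCOC(=O)c1c(NC(=O)CC#N)sc(C(=O)Nc2ccc(Cl)cc2)c1-c1ccccc1` gives 730 nM
- compound 3 `N#CCC(=O)Nc1sc(C(=O)Nc2ccc(Cl)cc2)c(-c2ccccc2)c1C#N` gives 390 nM

Compound 2 lies within the scatter of compound 1 and of compound 3, so these values set no order. Compound 4 `CCOC(=O)c1c(N)sc(C(=O)Nc2ccc(Cl)cc2)c1-c1ccccc1` differs from compound 2 by hydrogen in place of (cyanomethyl)carbonyl on a nitrogen on an aromatic ring. The closest evidence is the same change in reverse, a 1.8-fold lower number from compound 1 to compound 3 (0.25 log units; within the scatter), which is within the scatter. The other measured step, a 1.9-fold lower number from compound 2 to compound 3 (0.27 log units; within the scatter), concerns a different group. In this assay a small move towards a higher number is therefore expected, probably no larger than the scatter. The expected step is a 1.4-fold higher number from compound 2 to compound 4 (0.14 log units; within the scatter). Compound 4 is estimated at 1000 nM with an expected range from 450 nM to 2200 nM.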

Compound 4, half-maximal inhibitory concentration: 420 nM
Estimate against measurement, compound 4: 2.4-fold (0.38 log units) above; measured number below the stated range.
By their numbers in this assay, from the lowest: compounds 3, 4, 1 and 2 (each within the scatter of the next).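

In this assay, hydrogen in place of (cyanomethyl)carbonyl on the nitrogen gives a 1.7-fold lower number from compound 2 to compound 4 (0.24 log units; within the scatter), and ethoxycarbonyl in place of cyano on the aromatic carbon gives a 1.6-fold lower number from compound 1 to compound 4 (0.22 log units; within the scatter). Each step alone stays within the scatter, but the (cyanomethyl)carbonyl change does not read the same on the two cores: the same change on two cores in this assay, a 1.8-fold lower number (0.25 log units; within the scatter) from compound 1 to compound 3 and a 1.7-fold higher number (0.24 log units; within the scatter) from compound 4 to compound 2, 3.1-fold (0.49 log units) apart, beyond the scatter of two such steps. The cyano and ethoxycarbonyl exchange shows the same dependence on the core: the same change on two cores in this assay, a 1.9-fold lower number (0.27 log units; within the scatter) from compound 2 to compound 3 and a 1.6-fold higher number (0.22 log units; within the scatter) from compound 4 to compound 1, 3.1-fold (0.49 log units) apart, beyond the scatter of two such steps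

Going by these compounds, both gaps rest on the same four compounds, so whether this dependence extends to other compounds stays open. Also open, on these data alone, is what an acetyl group on the nitrogen, or a carboxylic acid on the aromatic carbon, would give on either core.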